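The compounds below may be only part of what the source reports. "The series", "measured", "known", "first", "only" and "open" are said of these compounds alone.

Compound 1 `Cc1c(C(C)n2cnc3ncc(-c4cnn(C)c4)nc32)ccc2ncccc12`: 206 nM
Compound 2 `COC(=O)c1ccc(-c2cnc3ncn(C(C)c4ccc5ncccc5c4C)c3n2)cc1F`: "not determined" (no result reported)

Both compounds share one core and differ in the group attached to it. In a functional assay on NCI-H1993 cells (Homo sapiens) for inhibition, read by CCK-8 assay, with a stated time of 72 h (a lower number here means a stronger inhibitor, a higher number a weaker inhibitor), compound 1 gives 206 nM. Compound 2 has no place on this scale: its entry reads "not determined" (no result reported), so there is no single number for it and nothing against which to size a change.

The next compound to be tested is compound 3 `Cc1c(C(C)n2cnc3ncc(-c4cnc5ccccc5c4)nc32)ccc2ncccc12`. The structural change is quinolin-3-yl in place of 3-fluoro-4-(methoxycarbonyl)phenyl on an aromatic carbon. Quinolin-3-yl takes the place of 3-fluoro-4-(methoxycarbonyl)phenyl on an aromatic carbon of the core, and the rest of the molecule stays the same.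

With no measured starting point on that side, no direction can be assigned to this step in this assay. Among the compounds with values here, the only anchor is compound 1 at 206 nM, so the expectation is for a result that does not differ from that number beyond the scatter, with wide uncertainty. For compound 3 the estimated value is 150 nM, with an expected range from 30 nM to 700 nM.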

Compound 3, half-maximal inhibitory concentration: 450 nM
The estimate for compound 3 lay 3.0-fold (0.48 log units) below the measured number; the measured number falls inside the stated range.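

In this assay, putting quinolin-3-yl in place of 1-methyl-1H-pyrazol-4-yl gives a 2.2-fold higher number from compound 1 to compound 3 (0.34 log units; beyond the scatter), a modest step but one beyond the scatter. Within the data shown here, it is the first readable change at this aromatic carbon of the shared core, and it shows that the group held there can shift the result, here toward a weaker inhibitor; the step from compound 2 cannot be read, as compound 2 has no number to start from. No measurement at hand accounts for the shift.

As far as these compounds go, with one readable step, it remains open whether the two-ring quinolin-3-yl group or some other feature of the change matters, and a single-ring group such as pyridin-3-yl, or a small group such as an amine, would help to separate these. Also open, from the compounds shown here alone, is how a phenyl group at this carbon behaves in this test, whether it carries the methyl ester of compound 2 or a free carboxylic acid.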